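One Methyl Added to the Carbamoyl of Compound 2

A few compounds are considered here, and "the series" means these few. Any claim that something is new, unique, unknown or untested is made for them only; others in the source may bear on it.

In a functional assay (strain AB) with Danio rerio as the target, read by microscopy, with a stated time of 1 h (on this read-out higher numbers stand for an effect only at larger amounts of compound and lower numbers for an effect already at smaller amounts), compound 2 (`CCN1CCc2c(sc(NC(=O)Nc3ccc(Cl)cc3)c2C(N)=O)C1`) gives 3120 nM and stands in the middle of the three measured numbers, with compound 3 (`CC(C)(C)OC(=O)CCN1CCc2c(sc(NC(=O)Nc3ccc(Cl)cc3)c2C(N)=O)C1`) lower at 1100 nM and compound 1 (`CCN1CCc2c(sc(NC(=O)Nc3cccc(Cl)c3Cl)c2C(N)=O)C1`) higher at 17400 nM on the same scale.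

Compound 4 (`CCN1CCc2c(sc(NC(=O)Nc3ccc(Cl)cc3)c2C(=O)NC)C1`) differs from compound 2 by one small change (methyl in place of hydrogen on an amide-type nitrogen) that turns carbamoyl into methylcarbamoyl. Going by the values given here, no measured step makes this change, so the evidence is only indirect. Having 4-chlorophenyl in place of 2,3-dichlorophenyl on an amide-type nitrogen came with a 5.6-fold lower number from compound 1 to compound 2 (0.75 log units; beyond the scatter) and having tert-butoxycarbonyl in place of hydrogen on a saturated chain carbon came with a 2.8-fold lower number from compound 2 to compound 3 (0.45 log units; beyond the scatter) in the same series. Both steps leave the carbamoyl group untouched, so they hint at how far one edit can move the number here but not which way this edit will move it.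

With compound 2 at 3120 nM as the anchor, no step beyond the scatter is expected, only a slight lean towards a higher number. The expected step is a 1.4-fold higher number from compound 2 to compound 4 (0.16 log units; within the scatter) and remains an estimate. Compound 4 is estimated at 4500 nM with an expected range from 1300 nM to 15000 nM when measured.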

Compound 4, half-maximal effective concentration: > 25000 nM
Compound 4 gave a limit, no number; the forecaster's own chance of this, stated with the estimate: 10%; middle value at least 5.5-fold (0.74 log units) from the limit.
By their numbers in this assay, from the lowest: compound 3; then compound 2; then compound 1. At a limit, above all of these: compound 4.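

Going by these compounds alone, until now every step in this assay left the carbamoyl group untouched, so compound 4 gives the first direct reading on this part of the molecule. With the rest of the structure held constant, methyl in place of hydrogen on this amide-type nitrogen came with an at least 8.0-fold higher number from compound 2 to compound 4 (0.90 log units; beyond the scatter), which shows that a single added carbon at this position can push the effect towards much larger amounts of compound, and that the unsubstituted carbamoyl of compound 2 is the better of the two forms seen here. For compound 4 the result is a limit and not a number, so this step gives only a lower bound on the size of the change: the limit of > 25000 nM in this assay, at which 1 of the 4 values shown sits.

One methyl on one parent says little about whether the loss follows from the missing amide hydrogen or from the added carbon, and an ethyl group, a longer chain on the same nitrogen, or a carboxylic acid or nitrile in place of the whole carbamoyl could help separate those readings. From the compounds shown here alone, it also remains open whether the same edit would carry the same penalty on compound 3, with its tert-butoxycarbonyl chain.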